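The source may report more compounds than this note shows. Statements on the series, on what has been measured and on what is new or still open speak of the compounds shown alone.

Series notes. Going by the values given here, the shared core carries a benzyloxy-chlorobenzyl group on the ring nitrogen; variation so far sits on the carbon two ring bonds from that nitrogen. Compound 1 `Cc1cc(C(N)=O)nn1Cc1cc(Cl)ccc1OCc1ccccc1` gives 126 nM in an assay on CHO-K1 cells for displacement of a labelled ligand from prostaglandin E2 receptor EP1 subtype (Homo sapiens); on this read-out higher numbers stand for weaker inhibition and lower numbers for stronger inhibition. Compound 2 `Cc1cc(C(=O)Nc2ccccc2)nn1Cc1cc(Cl)ccc1OCc1ccccc1` gives 39.8 nM in this assay, a step of a 3.2-fold lower number from compound 1 to compound 2 (0.50 log units; beyond the scatter). Compound 3 `Cc1cc(C(=O)NCc2ccncc2)nn1Cc1cc(Cl)ccc1OCc1ccccc1` gives 79.4 nM in this assay; the step from the parent amide is a 1.6-fold lower number from compound 1 to compound 3 (0.20 log units; within the scatter), and the step from the phenyl amide is a 2.0-fold higher number from compound 2 to compound 3 (0.30 log units; within the scatter). Compound 3 therefore stands second highest of the three numbers, close to compound 1 and separated from compound 2 only within the scatter.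

Compound 4 `Cc1cc(NC(=O)C2CCCC2)nn1Cc1cc(Cl)ccc1OCc1ccccc1` is not yet measured. Relative to compound 3 the change is (cyclopentylcarbonyl)amino in place of ((pyridin-4-yl)methyl)carbamoyl on an aromatic carbon: the amide direction is reversed and the pyridylmethyl is exchanged for a cyclopentyl. Among the compounds with values here, none of the measured steps covers a reversed amide; the two steps that touch this position, a 1.6-fold lower number from compound 1 to compound 3 (0.20 log units; within the scatter) and a 2.0-fold higher number from compound 2 to compound 3 (0.30 log units; within the scatter), only show that substituents on the amide nitrogen move the number within a narrow band. Within the data shown here, with no direct precedent, no step beyond the scatter is expected, and the estimate for compound 4 is 100 nM in this assay, between 30 nM and 400 nM, corresponding to an expected step of a 1.3-fold higher number from compound 3 to compound 4 (0.10 log units; within the scatter).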

Compound 4, half-maximal inhibitory concentration: 15.9 nM
Compound 4: the middle estimate sits 6.3-fold (0.80 log units) above what was measured; the whole stated range lies above it.
By their numbers in this assay, from the lowest: compound 4; then compounds 2, 3 and 1 (each within the scatter of the next, the first and the last beyond it).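

Going by these compounds alone, the reversed amide carrying cyclopentyl is the first change at this position to move the number beyond the scatter against each of the three earlier compounds in this assay (a 5.0-fold lower number from compound 3 to compound 4 (0.70 log units; beyond the scatter); a 2.5-fold lower number from compound 2 to compound 4 (0.40 log units; beyond the scatter); a 7.9-fold lower number from compound 1 to compound 4 (0.90 log units; beyond the scatter)). Substituents on the nitrogen of the carbamoyl group had spanned a narrow band, with only the phenyl step from the parent amide beyond the scatter, so compound 4 shows that this carbon tolerates an amide joined through its nitrogen and that such a group can give the strongest inhibition of the four. Nothing available accounts for this gain.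

The change from compound 3 to compound 4 alters both the amide direction and the substituent, so the share of each remains unresolved; a cyclopentylcarbamoyl group, or a benzoylamino group, on the same carbon would separate them. Also open, on these data alone, is how far the reversed amide can be varied, for example with a longer alkyl chain or a cyclohexyl ring in place of cyclopentyl, and whether a plain amine or a carboxylic acid on this carbon would hold the number.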